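A few compounds are considered here, and "the series" means these few. Any claim that something is new, unique, unknown or untested is made for them only; others in the source may bear on it.

Measured so far:
compound 1 `Cc1cccc(F)c1N(C)C(=O)c1ccc(-c2ccc(OS(N)(=O)=O)cc2)o1` — 150 nM
compound 2 `Cc1cc(F)ccc1N(C)C(=O)c1ccc(-c2ccc(OS(N)(=O)=O)cc2)o1` — 14 nM

In an assay on T47D cells for inhibition of Steryl-sulfatase (Homo sapiens), read by HPLC, with a stated time of 24 h (a higher number here means a weaker inhibitor, a lower number a stronger inhibitor), compound 2 gives 14 nM, the lowest of the two numbers shown; compound 1 gives 150 nM, and the step of an 11-fold lower number from compound 1 to compound 2 (1.03 log units; beyond the scatter) lies beyond the scatter. Compound 3 `Cc1ccncc1N(C)C(=O)c1ccc(-c2ccc(OS(N)(=O)=O)cc2)o1` is not yet measured. Its difference from compound 2 is 4-methylpyridin-3-yl in place of 4-fluoro-2-methylphenyl on an amide-type nitrogen. For the measured compounds named here, only one measured step touches the same place, the group on the amide-type nitrogen: the step of an 11-fold lower number from compound 1 to compound 2 (1.03 log units; beyond the scatter), which was large. That step shows the aryl group on this nitrogen can move this assay substantially, but it swaps one substituted phenyl for another, not for a pyridinyl, so it gives no direction for the present change. A step of moderate size, in either direction, is therefore expected, with a wide range. Compound 3 is estimated at 30 nM (range 8 nM to 120 nM), an expected step of a 2.1-fold higher number from compound 2 to compound 3 (0.33 log units; beyond the scatter).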

Compound 3, half-maximal inhibitory concentration: 820 nM
Compound 3: the middle estimate sits 27-fold (1.44 log units) below what was measured, outside the stated range (above it).
By their numbers in this assay, from the lowest: compound 2; then compound 1; then compound 3.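

In this assay, the move to 4-methylpyridin-3-yl on the amide-type nitrogen gives a 59-fold higher number from compound 2 to compound 3 (1.77 log units; beyond the scatter) and so ranks compound 3 as the weakest of the three, while a 5.5-fold higher number from compound 1 to compound 3 (0.74 log units; beyond the scatter) places it behind even the weaker of the two fluoro-methylphenyl compounds. For the compounds shown here, the earlier compounds showed only that rearranging groups on a carbon-only ring moves this assay; these steps show that a ring with one hetero atom and no fluorine can cost more than that rearrangement did. No measurement shown explains this loss.

Because fluorine leaves as the ring nitrogen enters, the compounds shown do not separate the two changes. Also open, going by these compounds, is how a fluorinated pyridine ring, or a chloro or methoxy group in place of the fluorine, would read in this assay.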